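From Acetyl to Benzoyl: Expected Cell Toxicity

The compounds below may be only part of what the source reports. "The series", "measured", "known", "first", "only" and "open" are said of these compounds alone.

Of the compounds shown here, three sharing one core have so far been tested in an ADME assay on HEK293-A cells (Homo sapiens) for cytotoxicity, read by MTT assay, with a stated time of 48 h; a lower number here means a stronger inhibitor, a higher number a weaker inhibitor. Compound 1 `O=C1O[C@@H](CO)CN1c1ccc(-n2cc(-c3ccccn3)cn2)c(F)c1` gives only a limit there, > 400 ug/mL. Compound 2 `O=C1O[C@@H](CN2CCC(O)CC2)CN1c1ccc(-n2cc(-c3ccccn3)cn2)c(F)c1` likewise gives only a limit, > 400 ug/mL. Compound 3 `CC(=O)OC[C@H]1CN(c2ccc(-n3cc(-c4ccccn4)cn3)c(F)c2)C(=O)O1` also gives only a limit, > 400 ug/mL. All three therefore sit at the same place: the limit of > 400 ug/mL in this assay, at which 3 of the 3 values shown sit. The steps among them, a step that the two limits leave unreadable from compound 1 to compound 2, a step that the two limits leave unreadable from compound 1 to compound 3 and a step that the two limits leave unreadable from compound 2 to compound 3, cannot be read in size. Each end of each of these steps is a limit rather than a number.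

Compound 4 `O=C(OC[C@H]1CN(c2ccc(-n3cc(-c4ccccn4)cn3)c(F)c2)C(=O)O1)c1ccccc1` has yet to be tested in this assay. It differs from compound 3 in one place: phenyl in place of methyl on a carbonyl carbon. Going by the values given here, none of the measured steps involves this change, and none of them yields a readable size, so they give no direction and no magnitude to carry over. What they do show is that every variation tried so far on the side chain left the result at the limit.

On that basis compound 4 is expected to behave as compound 3 does, with an estimated step of a number no higher from compound 3 to compound 4 (the limit leaves the size open), meaning no change beyond the scatter. The estimate for compound 4 in this assay is 400 ug/mL, within the range 200 ug/mL to 800 ug/mL, most probably reported again as a limit.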

Compound 4, half-maximal inhibitory concentration: > 400 ug/mL
Compound 4: only a limit was reported; the forecaster's own chance of this, stated with the estimate: 85%; the middle value sits exactly at the limit.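

Compound 4 also gives only a limit in this assay, > 400 ug/mL. Its steps from compound 1, compound 2 and compound 3 therefore cannot be read in size, and all four compounds stand together: the limit of > 400 ug/mL in this assay, at which 4 of the 4 values shown sit.

The compounds shown leave open whether these side-chain changes differ at all in cytotoxicity, as none has a value that is a number.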